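Aroylurea thiazole hydrazones: aryl swap on the acylurea carbonyl

The source may report more compounds than this note shows. Statements on the series, on what has been measured and on what is new or still open speak of the compounds shown alone.

Among the compounds with values here, the series shares one core; the three measured members are compound 1 `CN(C(=O)NC(=O)c1ccc([N+](=O)[O-])cc1)c1nc(C(F)(F)F)c(C(=O)N/N=C/c2cccc(C(F)(F)F)c2)s1`, compound 2 `CN(C(=O)NC(=O)c1ccc(Cl)cc1Cl)c1nc(C(F)(F)F)c(C(=O)N/N=C/c2ccc(C(F)(F)F)cc2)s1` and compound 3 `Cc1nc(N(C)C(=O)NC(=O)c2ccc(Cl)cc2Cl)sc1C(=O)N/N=C/c1ccc(C(F)(F)F)cc1`. In a functional assay on HepG2 cells (Homo sapiens) for inhibition, read by MTT assay, with a stated time of 72 h (a lower number here means a stronger inhibitor, a higher number a weaker inhibitor), compound 1 gives 4.73 ug/mL and compound 2 gives 12.4 ug/mL, so compound 2 holds the higher of the two numbers. Compound 3 gives only a limit, > 100 ug/mL, in this assay. Within the data shown here, the one measured step, an at least 8.0-fold higher number from compound 2 to compound 3 (0.90 log units; beyond the scatter), changes the trifluoromethyl on the core, not the acylurea aryl, and its size rests on (the limit of > 100 ug/mL in this assay, at which 1 of the 3 values shown sits).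

Compound 4 `CN(C(=O)NC(=O)c1cccc(C(F)(F)F)c1)c1nc(C(F)(F)F)c(C(=O)N/N=C/c2ccc(C(F)(F)F)cc2)s1` differs from compound 2 by 3-(trifluoromethyl)phenyl in place of 2,4-dichlorophenyl on a carbonyl carbon. Among the measured compounds shown here, no measured step covers a change at that carbonyl carbon; compound 1 carries a different aryl there but also a different benzylidene part, so its two values with compound 2 show only that such a change can move the number modestly. Compound 4 is therefore expected to stay near compound 2, with a 1.2-fold lower number from compound 2 to compound 4 (0.09 log units; within the scatter) not beyond the scatter. The estimate for compound 4 in this assay is 10 ug/mL, between 3 ug/mL and 40 ug/mL.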

Compound 4, half-maximal inhibitory concentration: 7.71 ug/mL
Estimate against measurement, compound 4: 1.3-fold (0.11 log units) above, and the stated range covers the measured number.
By their numbers in this assay, from the lowest: compounds 1, 4 and 2 (each within the scatter of the next, the first and the last beyond it). At a limit, above all of these: compound 3.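

Within the data shown here, at the carbonyl carbon whose other neighbour is the amide-type nitrogen, the swap of 2,4-dichlorophenyl for 3-(trifluoromethyl)phenyl gives the first single-place reading of this position in this assay: a 1.6-fold lower number from compound 2 to compound 4 (0.21 log units; within the scatter). Among these compounds, the earlier single-place step concerned the core, so this is the first sign that the acylurea aryl can carry a different substitution, here two chlorines exchanged for one trifluoromethyl, with the two values staying within the scatter of each other. No measured property shown here bears on this result.

Still open, from the compounds shown here alone, is how a dimethylamino group or a carboxylic acid on this aryl, or a saturated cyclohexyl ring in its place, would read in this assay. The nitro-bearing aryl of compound 1 also has no partner differing in that one place.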